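The source may hold more compounds than are shown below. What is called first, only, known or untested is meant among the compounds shown, and "the series" means these compounds.

In an ADME assay on RAW264.7 cells (Mus musculus) for cytotoxicity, read by MTT assay, with a stated time of 48 h (on this read-out higher numbers stand for lower toxicity in this test and lower numbers for higher toxicity in this test), compound 2 `C#CCN(c1nc(-c2ccc(Cl)cc2)no1)C1CCCCC1` gives 15.1 ug/mL, the lowest of the three numbers shown. Compound 1 `CC(=O)OC[C@H]1O[C@H](OC[C@H](Cn2cc(-c3ccc(-c4noc(NC5CCCCC5)n4)cc3)nn2)OC(C)=O)C=C[C@@H]1OC(C)=O` stands nearest to it, giving 16.3 ug/mL in this assay, a gap within the scatter, so no order between the two can be read. Compound 3 `CC(=O)OC[C@H]1O[C@H](OC[C@@H](Cn2cc(CN(c3nc(-c4ccc(C)cc4)no3)C3CCCCC3)nn2)OC(C)=O)C=C[C@@H]1OC(C)=O` stands furthest, giving 45.3 ug/mL in this assay, a gap beyond the scatter. Compound 4 `C#CCN(c1nc(-c2ccc(F)cc2)no1)C1CCCCC1` differs from compound 2 by fluoro in place of chloro on an aromatic carbon. Among the compounds with values here, no pair of measured compounds shows this change, so the expectation rests on compound 2 alone. The step of a 1.0-fold lower number from compound 2 to compound 4 (0.00 log units; within the scatter) is expected to stay within the scatter, with no clear direction. Compound 4 is therefore estimated at 15 ug/mL, with a range from 8 ug/mL to 30 ug/mL.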

Compound 4, half-maximal cytotoxic concentration: 20.9 ug/mL
Estimate against measurement, compound 4: 1.4-fold (0.14 log units) below; low and high end bracket the measured number.
By their numbers in this assay, from the lowest: compounds 2, 1 and 4 (each within the scatter of the next); then compound 3.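

In this assay, within the data shown here, replacing chloro with fluoro on this aromatic carbon gives a 1.4-fold higher number from compound 2 to compound 4 (0.14 log units; within the scatter), the first direct reading of this swap. At this place, the two halogens cannot be told apart by this read-out, so neither compound can be ranked above the other. Nothing shown here explains this result. As far as these compounds go, whether an amine or a carboxylic acid at this place would move the number beyond the scatter stays open. So does whether fluoro and chloro would also read alike on the larger core of compound 3.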